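This account rests on a few compounds, and the source may have more. Where it says the series, first, only, none or still open, it means among the compounds named here.

Compound 2 `CCCCCCCCCCCSC(=S)C1=C(Nc2ccc(Cl)cc2Cl)CC(C)(C)CC1=O` carries an undecyl chain on the sulfur of its dithioester. In a functional assay on PBMC cells (Homo sapiens) for inhibition, read by ELISA, with a stated time of 18 h (a higher number here means a weaker inhibitor, a lower number a stronger inhibitor), compound 2 gives > 20 ug/mL, which is a limit of the assay rather than a number. Its neighbours sit at the same limit: compound 1 `CCCCSC(=S)C1=C(Nc2ccc(Cl)cc2Cl)CC(C)(C)CC1=O`, with a butyl chain, gives > 20 ug/mL, a limit. Compound 3 `CC1(C)CC(=O)C(C(=S)SCCO)=C(Nc2ccc(Cl)cc2Cl)C1`, with a hydroxyethyl chain, gives > 20 ug/mL, again a limit. The steps between them are therefore unreadable: a step that the two limits leave unreadable from compound 1 to compound 2, a step that the two limits leave unreadable from compound 1 to compound 3 and a step that the two limits leave unreadable from compound 2 to compound 3 all rest on (the limit of > 20 ug/mL in this assay, at which 3 of the 3 values shown sit).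

Compound 4 `CCCCCCCCCCCSC(=S)C1=C(Nc2ccc(Cl)cc2)CC(C)(C)CC1=O` differs from compound 2 on the aromatic ring: hydrogen in place of chloro on an aromatic carbon

Going by the values given here, none of the measured steps touches this ring, so they give no size for the change. Every value shown is a limit, and nothing suggests that removing one chloro group lifts the series above it. Compound 4 is therefore expected to sit near the same limit, with the step from compound 2 estimated as a step that the limit leaves unreadable from compound 2 to compound 4. The estimate for compound 4 in this assay is 25 ug/mL, within a range of 6 ug/mL to 80 ug/mL.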

Compound 4, half-maximal inhibitory concentration: > 20 ug/mL
Compound 4 ended at the assay's limit; the forecaster's own chance of this, stated with the estimate: 80%; the middle value does not contradict the limit.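

Compound 2 and compound 4 both sit at a limit of the assay rather than at a number, so no size can be read for the change between them: the limit of > 20 ug/mL in this assay, at which 4 of the 4 values shown sit.

In this assay the compounds shown leave open how strong any of them really is, and whether the chloro group or the chain on the sulfur matters for that.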